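Cytotoxicity notes: pyrrole for pyrrolidine on the shared core

A few compounds are considered here, and "the series" means these few. Any claim that something is new, unique, unknown or untested is made for them only; others in the source may bear on it.

Measured in an ADME assay on HEL cells (Homo sapiens) for cytotoxicity, with a stated time of 3 days; on this read-out lower numbers stand for higher toxicity in this test and higher numbers for lower toxicity in this test:
- compound 1 `Cc1cc(Sc2ccc(O)cc2)cn2c(CSCCc3ccccc3)cnc12` gives 100 ug/mL.
- compound 2 `Cc1cc(N2CCCC2)c2ncc(CSCCc3ccccc3)n2c1` gives only an assay limit, > 100 ug/mL.
- compound 3 `Cc1cc(N2CCCC2)c2ncc(CSCc3ccccc3)n2c1` gives 52 ug/mL.

Compound 3 holds the lowest of the two numbers; its nearest neighbour is compound 1, and the gap between them is within the scatter. Going by the values given here, the only counted step, an at least 1.9-fold lower number from compound 2 to compound 3 (0.28 log units; that floor lies within the scatter), is a change elsewhere on the core and reaches a limit, so it does not speak to the change now considered.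

Compound 4 `Cc1cc(-n2cccc2)c2ncc(CSCc3ccccc3)n2c1` differs from compound 3 by 1H-pyrrol-1-yl in place of pyrrolidin-1-yl on an aromatic carbon. Among the compounds with values here, no measured step bears on this swap, so the step of a 1.0-fold lower number from compound 3 to compound 4 (0.02 log units; within the scatter) is expected to stay within the scatter. Compound 4 is therefore estimated at 50 ug/mL, with a range from 20 ug/mL to 100 ug/mL in this assay.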

Compound 4, half-maximal cytotoxic concentration: 15 ug/mL
Compound 4: middle estimate off by 3.3-fold (0.52 log units), on the high side; measured number below the stated range.
By their numbers in this assay, from the lowest: compound 4; then compounds 3 and 1 (each within the scatter of the next).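

In this assay, going by these compounds alone, the change at this aromatic carbon, ortho to a fused ring, gives a 3.5-fold lower number from compound 3 to compound 4 (0.54 log units; beyond the scatter), the first step read at this position. Pyrrolidin-1-yl and 1H-pyrrol-1-yl have the same counts of heavy atoms, donors and acceptors, so ring aromaticity is the counted difference that goes with this step. The sulfur-side comparison remains unsized, since compound 2 gives only an assay limit: the limit of > 100 ug/mL in this assay, at which 1 of the 4 values shown sits.

On these data alone, whether a piperidine ring or a dimethylamino group here would track compound 3 or compound 4 remains open. So does whether the same swap gives a similar step on the longer chain of compound 2.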